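A few compounds are considered here, and "the series" means these few. Any claim that something is new, unique, unknown or untested is made for them only; others in the source may bear on it.

Of the compounds shown here, three on the shared core have been read in a functional assay on HCT-116 cells (Homo sapiens) for cytotoxicity, read by MTT assay, with a stated time of 72 h; on this read-out higher numbers stand for weaker inhibition and lower numbers for stronger inhibition. Compound 1 (`C[C@@H](Nc1c(C(=O)NCc2ccc(F)cc2)nc(Br)c2cccnc12)c1ccccc1`) gives > 20000 nM, which is a limit and not a number. Compound 2 (`CN(C)CCCNc1c(C(=O)NCc2ccc(F)cc2)nc(Br)c2cccnc12`) gives > 10000 nM, which is also a limit. Among the measured compounds shown here, compound 3 (`N[C@H]1CC[C@H](Nc2c(C(=O)NCc3ccc(F)cc3)nc(Br)c3cccnc23)CC1`) gives 4000 nM, the only actual number in the set. The standing of compound 3 therefore rests on comparison with the two limits of compound 1 and compound 2.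

The next compound to be read is compound 4 (`CNCCCNc1c(C(=O)NCc2ccc(F)cc2)nc(Br)c2cccnc12`). The change is 3-(methylamino)propyl in place of 4-aminocyclohexyl on a nitrogen on an aromatic ring.

For the measured compounds named here, two measured steps bear on this. The nearer one is an at least 2.5-fold lower number from compound 2 to compound 3 (0.39 log units; beyond the scatter), where 4-aminocyclohexyl replaced 3-(dimethylamino)propyl, a chain close in name to the one entering here. The other is an at least 5.0-fold lower number from compound 1 to compound 3 (0.69 log units; beyond the scatter), which also favours 4-aminocyclohexyl but starts from the more distant 1-phenylethyl. The step that the two limits leave unreadable from compound 1 to compound 2 cannot be read and adds nothing. Going by an at least 2.5-fold lower number from compound 2 to compound 3 (0.39 log units; beyond the scatter), losing 4-aminocyclohexyl is expected to move compound 4 to a higher number in this assay, by a modest amount, and a result at a limit would not be surprising.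

The estimated step is a 2.3-fold higher number from compound 3 to compound 4 (0.35 log units; beyond the scatter). For compound 4 the expected value is 9000 nM, with an estimated range of 3000 nM to 25000 nM.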

Compound 4, half-maximal inhibitory concentration: > 10000 nM
Compound 4 ended at the assay's limit; the forecaster's own chance of this, stated with the estimate: 40%; middle value at least 1.1-fold (0.04 log units) away from the limit.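

In this assay, among the compounds shown here, the change from 4-aminocyclohexyl to 3-(methylamino)propyl on a nitrogen on an aromatic ring gives an at least 2.5-fold higher number from compound 3 to compound 4 (0.39 log units; beyond the scatter), the first reading of a step away from compound 3 to a chain that keeps one amine nitrogen but has no ring. With compound 4 added, both 3-(dimethylamino)propyl and 3-(methylamino)propyl have been tested at this position, and neither gives a number; of the four compounds, only compound 3, with its six-membered non-aromatic ring of carbon only, does, while compound 1 also ends at a limit. The steps among compound 1, compound 2 and compound 4 cannot be read, and compound 2 and compound 4 share one limit, so hydrogen in place of methyl on the amine nitrogen shows no readable effect: the limit of > 10000 nM in this assay, at which 2 of the 4 values shown sit.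

As far as these compounds go, how far compound 2 and compound 4 lie past that limit stays unknown, so any difference between them remains open. Whether the carbon ring or its amine accounts for the number of compound 3 is also open, and a plain cyclohexyl or a 3-aminopropyl chain at this position would help separate the two.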